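The source may report more compounds than this note shows. Statements on the series, on what has been measured and on what is new or still open speak of the compounds shown alone.

Measured in a functional assay on MCF7 cells (Homo sapiens) for antiproliferative activity; a higher number here means a weaker inhibitor, a lower number a stronger inhibitor:
- compound 1 `Cc1ccc(C(=O)Nc2ccc(O)c3c(=O)cc(-c4ccccc4Cl)oc23)cc1` gives 10000 nM
- compound 2 `Cc1ccc(C(=O)Nc2c(O)cc(O)c3c(=O)cc(-c4ccccc4Cl)oc23)cc1` gives 9700 nM
- compound 3 `C[C@H](NC(=O)OC(C)(C)C)C(=O)Nc1ccc(O)c2c(=O)cc(-c3ccccc3Cl)oc12` gives 5500 nM

Compound 1 sits level with the other two in this assay. Placing hydroxy in place of hydrogen on an aromatic carbon gives a 1.0-fold lower number from compound 1 to compound 2 (0.01 log units; within the scatter). Placing 1-((tert-butoxycarbonyl)amino)ethyl in place of 4-methylphenyl on a carbonyl carbon gives a 1.8-fold lower number from compound 1 to compound 3 (0.26 log units; within the scatter). Among these three compounds, neither change moves the number beyond normal measurement noise.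

Compound 4 `O=c1cc(-c2ccccc2Cl)oc2c(NS(=O)(=O)c3ccccc3)ccc(O)c12` has not yet been measured. It keeps the core of compound 1 but has phenylsulfonyl in place of (4-methylphenyl)carbonyl on a nitrogen on an aromatic ring. For the measured compounds named here, no measured compound carries phenylsulfonyl, so no measured step tests this change directly. The closest evidence is the change on the same nitrogen's acyl group, which gave a 1.8-fold lower number from compound 1 to compound 3 (0.26 log units; within the scatter). That single flat step is weak support, but it gives no reason to expect a large move. The expected change is therefore a 1.3-fold lower number from compound 1 to compound 4 (0.10 log units; within the scatter), which would be no real step beyond the scatter. For compound 4 the estimated value is 8000 nM, with an expected range of 3000 nM to 20000 nM.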

Compound 4, half-maximal inhibitory concentration: 16000 nM
For compound 4 the middle estimate is 2.0-fold (0.30 log units) below the measured one, within the range that was stated.
By their numbers in this assay, from the lowest: compounds 3, 2, 1 and 4 (each within the scatter of the next, the first and the last beyond it).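

On the nitrogen on an aromatic ring, phenylsulfonyl in place of (4-methylphenyl)carbonyl gives, in this assay, a 1.6-fold higher number from compound 1 to compound 4 (0.20 log units; within the scatter). The earlier step at this nitrogen kept the carbonyl and altered only what hangs on it, whereas this one replaces the carbonyl link itself, and the number still stays within the scatter. Among the compounds shown, then, neither replacement at this nitrogen moves the number measurably from that of compound 1, although no information is available on what lies behind this flat result.

The swap also removes the methyl group from the aromatic ring, so a 4-methylphenylsulfonyl group on the same nitrogen would be needed to separate the effect of the sulfonyl link from that of the methyl. As far as these compounds go, it also remains open whether a different kind of group at this position, such as a free amine, a carboxylic acid or a longer alkyl chain, would shift the number beyond the scatter.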